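Benzyl Replaces Butyl in an Alpha-L-Fucosidase Inhibitor Series

The source may hold more compounds than are shown below. What is called first, only, known or untested is meant among the compounds shown, and "the series" means these compounds.

Measured compounds:
- compound 1 `CCCCNC1=NC2CC(C)C(O)C(O)C2O1`: 140000 nM
- compound 2 `CC1CC2N=C(Nc3ccccc3)OC2C(O)C1O`: 7600 nM

In an assay on isolated protein (Bos taurus) for inhibition of tissue alpha-L-fucosidase (Homo sapiens) (on this read-out lower numbers stand for stronger inhibition and higher numbers for weaker inhibition), compound 1 gives 140000 nM, the highest of the two numbers seen so far, and therefore the weaker of the two inhibitors. Its nearest neighbour, compound 2, gives 7600 nM in this assay. For the measured compounds named here, the one measured step, an 18-fold lower number from compound 1 to compound 2 (1.27 log units; beyond the scatter), shows that a phenyl ring directly on the amine nitrogen is a large improvement over a butyl chain there.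

Compound 3 `CC1CC2N=C(NCc3ccccc3)OC2C(O)C1O` has not yet been measured. It differs from compound 1 by phenyl in place of propyl on a saturated chain carbon bound to an amine nitrogen, so the aromatic ring is carried one carbon further from the nitrogen than in compound 2. Going by the values given here, the only step that bears on this change is an 18-fold lower number from compound 1 to compound 2 (1.27 log units; beyond the scatter), which shows a large gain when an aromatic ring enters in this region of the shared core. Among the compounds with values here, a benzyl group is not a phenyl group, however, and compound 2 is the only guide, so the expected step is taken as smaller than that one. Compound 3 is therefore expected to give 25000 nM in this assay, with a range of 8000 nM to 70000 nM, which means an expected step of a 5.6-fold lower number from compound 1 to compound 3 (0.75 log units; beyond the scatter).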

Compound 3, half-maximal inhibitory concentration: 72000 nM
The estimate for compound 3 lay 2.9-fold (0.46 log units) below the measured number; measured number above the stated range.
By their numbers in this assay, from the lowest: compound 2; then compounds 3 and 1 (each within the scatter of the next).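

Phenyl in place of propyl on a saturated chain carbon bound to an amine nitrogen gives a 1.9-fold lower number from compound 1 to compound 3 (0.29 log units; within the scatter) in this assay, so adding an aromatic ring in this region of the shared core does not by itself set a compound apart from compound 1. The large gain in an 18-fold lower number from compound 1 to compound 2 (1.27 log units; beyond the scatter) is therefore tied to phenyl placed on the amine nitrogen and does not carry over to phenyl on a saturated chain carbon bound to that nitrogen, as the printed numbers show: compound 2 gives 7600 nM and compound 3 gives 72000 nM in this assay.

Still open, on these data alone, is whether a phenethyl group on the amine nitrogen, with its longer chain, would stay close to compound 3, and whether a methoxy or chloro group on the phenyl ring of compound 2 would change its number. A cyclohexyl group in place of phenyl on the amine nitrogen would show whether compound 2 owes its number to the aromatic ring or simply to a six-membered ring there. Nothing measured on these compounds gives a reason for the contrast between compound 2 and compound 3.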